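This account rests on a few compounds, and the source may have more. Where it says the series, first, only, none or still open, it means among the compounds named here.

Measured compounds:
Compound 1 `O=C(CCSc1ncc(-c2ccccc2)o1)N1CCCC1` gives 11 mL/min/g in an ADME assay on microsomes from liver (Homo sapiens) for metabolic stability, read by LC-MS, using NADPH, with a stated time of 45 min, tested at 0.5 uM; a lower number here means slower removal, a higher number faster removal of the compound.
Compound 2 `O=C(CCSc1nc2cc(Cl)ccc2o1)NC1CCCC1` gives 11.3 mL/min/g in this assay.
Compound 3 `O=C(CCSc1nc2ccc(Cl)cc2o1)N1CCCC1` gives 6.6 mL/min/g in this assay.

Compound 2 shows the highest figure of the three, yet its gaps to compound 1 and to compound 3 both fall within the usual scatter, so the three numbers cannot be told apart with confidence. Compound 4 `CN(C)C(=O)CCSc1nc2cc(Cl)ccc2o1` has not yet been measured. It differs from compound 2 in one place: dimethylamino in place of cyclopentylamino on a carbonyl carbon. For the measured compounds named here, no measured pair shows this change, so its effect can only be guessed. In this assay a modest step toward a smaller number, or none beyond the scatter, is expected. The step from compound 2 to compound 4 is estimated at a 1.4-fold lower number from compound 2 to compound 4 (0.15 log units; within the scatter). Compound 4 is expected to give 8 mL/min/g, with a range from 4 mL/min/g to 16 mL/min/g.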

Compound 4, intrinsic clearance in a liver preparation (reported as CLH), per the amount of preparation that the assay uses: 2.7 mL/min/g
Compound 4: the middle estimate sits 3.0-fold (0.47 log units) above what was measured; the whole stated range lies above it.
By their numbers in this assay, from the lowest: compound 4; then compounds 3, 1 and 2 (each within the scatter of the next).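

For the compounds shown here, replacing cyclopentylamino with dimethylamino on a carbonyl carbon lowers the number in this assay by more than the scatter (a 4.2-fold lower number from compound 2 to compound 4 (0.62 log units; beyond the scatter)), the first step in this set that can be read. The earlier compounds shown here differed in more than one place, so none could tie a change to this position alone. This swap removes the ring and the amide hydrogen together, and nothing measured here explains the drop.

Which of those two losses matters stays open, and methylamino, which keeps the amide hydrogen without a ring, could separate them. Whether the same swap works on the core of compound 1 is also unknown.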